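Chloro for Propyl on the Side Chain of Compound 1

This account rests on a few compounds, and the source may have more. Where it says the series, first, only, none or still open, it means among the compounds named here.

Compound 1 `CCCCCCc1cc2cn(Cc3cn(Cc4ccccc4)nn3)c(=O)nc2o1` gives 67000 nM in a functional assay on CFPAC-1 cells (Homo sapiens) for antiproliferative activity, read by MTT assay, with a stated time of 72 h; a lower number here means a stronger inhibitor, a higher number a weaker inhibitor.
Compound 2 `O=c1nc2oc(C3CC3)c(C#CC3CC3)c2cn1Cc1cn(-c2ccccc2F)nn1` gives 54500 nM in this assay.
Compound 3 `CCCCCCc1cc2cn(Cc3cn(-c4ccccc4F)nn3)c(=O)nc2o1` reaches only the limit > 100000 nM in this assay, which is a limit of the assay and not a number.

Of the two compounds that give a number in this assay, compound 1 gives the higher one, but compound 1 and compound 2 lie within the usual scatter of each other, so no order between them can be read. For the measured compounds named here, the only step measured in one place is an at least 1.4-fold higher number from compound 1 to compound 3 (0.17 log units; that floor lies within the scatter); its size is set by the limit of > 100000 nM in this assay, at which 1 of the 3 values shown sits, and its floor lies within the scatter.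

Compound 4 `O=c1nc2oc(CCCCl)cc2cn1Cc1cn(Cc2ccccc2)nn1` differs from compound 1 by chloro in place of propyl on a saturated chain carbon, three bonds along the chain from an aromatic carbon. Going by the values given here, none of the measured steps touches this part of the shared core, so there is no measured evidence that bears on this change. Compound 4 is therefore expected to show a 1.0-fold higher number from compound 1 to compound 4 (0.02 log units; within the scatter), that is, no step beyond the scatter. The estimate for compound 4 in this assay is 70000 nM, with a range from 30000 nM to 150000 nM; this range reaches the limit of the assay, so compound 4 may also be reported only as a limit.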

Compound 4, half-maximal inhibitory concentration: 23500 nM
For compound 4 the middle estimate is 3.0-fold (0.47 log units) above the measured one; measured number outside the range, below it.
By their numbers in this assay, from the lowest: compound 4; then compounds 2 and 1 (each within the scatter of the next). At a limit, above all of these: compound 3.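

In this assay, for the compounds shown here, the side chain gives the first step in one place whose size can be read as beyond the scatter: a 2.9-fold lower number from compound 1 to compound 4 (0.46 log units; beyond the scatter). The only earlier step in one place, an at least 1.4-fold higher number from compound 1 to compound 3 (0.17 log units; that floor lies within the scatter), changed the group on an aromatic nitrogen and left the side chain untouched, so the far end of the chain is now shown to be a place where a single change moves the number, though the step is modest. The change replaces hexyl with 3-chloropropyl, so the chain loses carbon and gains chlorine in the same step, and no measurement shown gives a reason for the lower number.

The compounds shown leave open whether the chlorine itself or the shorter chain carries this step, which a plain propyl chain, or a 3-aminopropyl or 3-hydroxypropyl chain, would help to separate. They also leave open whether the same change would give a step of similar size with 2-fluorophenyl in place of benzyl on the aromatic nitrogen.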